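The source may report more compounds than this note shows. Statements on the series, on what has been measured and on what is new or still open speak of the compounds shown alone.

Measured so far:
compound 1 `CC#CCOC(=O)/C=C(C)/C=C/CC(C)CCCC(C)C` — 6.4
compound 2 `CSC(=O)/C=C(C)/C=C/CC(C)CCCC(C)C` — 7.44

In a physicochemical assay for lipophilicity (a lower number here means a more polar compound, a higher number a more lipophilic compound), compound 2 stands highest of the two numbers; the nearest is compound 1, whose value sits a number 1.04 log units higher from compound 1 to compound 2 (beyond the scatter) away when read from compound 1 to compound 2, a step beyond the scatter, so the order of the two is clear.

Compound 3 `CCCC(=O)/C=C(C)/C=C/CC(C)CCCC(C)C` is not yet measured in this assay. It differs from compound 2 by propyl in place of methylsulfanyl on a carbonyl carbon.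

Among the measured compounds shown here, only one measured step bears on this, and only loosely: a number 1.04 log units higher from compound 1 to compound 2 (beyond the scatter) shows that exchanging the group on the carbonyl carbon can shift the read-out by a large amount, but that step swapped (but-2-yn-1-yl)oxy for methylsulfanyl, not methylsulfanyl for propyl, so it gives direction of scale rather than direction of sign. For the measured compounds named here, no measured pair exchanges a methylsulfanyl for a propyl group. On that basis a modest step upward is expected, near the edge of the scatter: a number 0.26 log units higher from compound 2 to compound 3 (within the scatter). Compound 3 is therefore estimated at 7.7, with a range of 7.1 to 8.3.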

Compound 3, partition coefficient: 6.81
Compound 3: the middle estimate sits 0.89 log units above what was measured; measured number below the stated range.
By their numbers in this assay, from the lowest: compound 1; then compound 3; then compound 2.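

In this assay the number at this position does not follow the heavy-atom count of the group on the carbonyl carbon alone: propyl has more heavy atoms than methylsulfanyl and no hydrogen-bond acceptor, yet the exchange gives a number 0.63 log units lower from compound 2 to compound 3 (beyond the scatter) on the shared core. The exchange of (but-2-yn-1-yl)oxy for propyl gives a number 0.41 log units higher from compound 1 to compound 3 (beyond the scatter) and so places propyl between the other two groups, with all three compounds separated beyond the scatter and methylsulfanyl, not the all-carbon propyl, at the top of the order. Nothing measured alongside these values accounts for this order.

Still open, as far as these compounds go, is whether the high number of compound 2 belongs to the sulfur link itself or to methylsulfanyl in particular, which a longer chain on the sulfur, such as ethylsulfanyl, or a longer chain in place of propyl, such as butyl, would help to separate. Also open is where a nitrogen-linked group on the same carbonyl carbon, such as a dimethylamino group, would fall relative to the three groups shown.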